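This account rests on a few compounds, and the source may have more. Where it says the series, first, only, none or still open, it means among the compounds named here.

In an ADME assay on HepG2 cells (Homo sapiens) for cytotoxicity, read by resazurin assay, with a stated time of 24 h (a higher number here means that more compound is tolerated, a lower number that less compound is tolerated), compound 1 `COc1cc(C=Cc2ccc3ccccc3c2)c(C(=O)O)c(OC)c1` gives > 100000 nM as a limit of the assay and not as a number. Compound 2 `CCN(CC)C(=O)c1c(CCc2ccc3ccccc3c2)cc(OC)cc1OC` gives 59000 nM and compound 3 `Cc1cc(O)c(C(=O)O)c(CCc2ccc3ccccc3c2)c1` gives 38000 nM in the same read-out, two values within the scatter of each other. Going by the values given here, compound 4 `CCN(CC)C(=O)c1c(CCc2ccc3ccccc3c2)cccc1OC` carries hydrogen in place of methoxy on an aromatic carbon para to a diethylcarbamoyl group hydrogen in place of methoxy on an aromatic carbon as its one difference from compound 2. Among the compounds with values here, no measured pair isolates this replacement. With compound 2 at 59000 nM as the reference, no step beyond the scatter is expected in this assay for this replacement. The expected value for compound 4 is 50000 nM with an estimated range of 25000 nM to 100000 nM for the measurement to come.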

Compound 4, half-maximal cytotoxic concentration: 35800 nM
Estimate against measurement, compound 4: 1.4-fold (0.15 log units) above; the measured number falls inside the stated range.
By their numbers in this assay, from the lowest: compounds 4, 3 and 2 (each within the scatter of the next). At a limit, above all of these: compound 1.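

In this assay, going by these compounds alone, hydrogen in place of methoxy on the aromatic carbon para to the diethylcarbamoyl group gives a 1.6-fold lower number from compound 2 to compound 4 (0.22 log units; within the scatter), the first step between compounds that differ in one place. On this core, the methoxy at this position can therefore be lost with no step beyond the scatter. No measurement at hand points to a cause for this step.

On these data alone, whether an amine or a longer alkoxy chain at this position would also stay within the scatter remains open. So does the same replacement on a core carrying a carboxylic acid in place of the diethylcarbamoyl group.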